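Substituent exchange on the shared core: estimate for compound 4

The compounds below may be only part of what the source reports. "The series", "measured", "known", "first", "only" and "open" are said of these compounds alone.

Measured so far in a functional assay for antagonist activity at transient receptor potential cation channel subfamily V member 1 (Homo sapiens), read by FLIPR; on this read-out lower numbers stand for stronger inhibition and higher numbers for weaker inhibition:
compound 1 `CCS(=O)(=O)Nc1cccnc1-c1ccc(C(=O)Nc2ccc(C(C)(C)C)cc2)cc1`: 49 nM
compound 2 `CC(C)(C)c1ccc(NC(=O)c2ccc(-c3ncccc3N(S(C)(=O)=O)S(C)(=O)=O)cc2)cc1`: 0.8 nM
compound 3 `CN(C)Cc1cccnc1-c1ccc(C(=O)Nc2ccc(C(C)(C)C)cc2)cc1`: 746 nM

Compound 3 stands at the highest number of the three, set apart from both others by a 15-fold higher number from compound 1 to compound 3 (1.18 log units; beyond the scatter) and by a 930-fold higher number from compound 2 to compound 3 (2.97 log units; beyond the scatter). Compound 4 `CC(C)(C)c1ccc(NC(=O)c2ccc(-c3ncccc3-c3nn[nH]n3)cc2)cc1` differs from compound 3 by 2H-tetrazol-5-yl in place of (dimethylamino)methyl on an aromatic carbon. Going by the values given here, the two steps that bear on this position show that exchanging the (dimethylamino)methyl group moves the read-out in this assay by large amounts toward lower numbers; no measured step involves a tetrazolyl group, so the size for compound 4 is uncertain. Compound 4 is expected to give a lower number than compound 3, a step of about a 5.0-fold lower number from compound 3 to compound 4 (0.70 log units; beyond the scatter). The estimate for compound 4 in this assay is 150 nM, with a range from 30 nM to 800 nM.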

Compound 4, half-maximal inhibitory concentration: > 4000 nM
Compound 4 ended at the assay's limit; the forecaster's own chance of this, stated with the estimate: 5%; middle value at least 26-fold (1.42 log units) from the limit.
By their numbers in this assay, from the lowest: compound 2; then compound 1; then compound 3. At a limit, above all of these: compound 4.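

In this assay compound 4 stands at a limit of the assay, not at a number: the limit of > 4000 nM in this assay, at which 1 of the 4 values shown sits. Exchanging (dimethylamino)methyl at this position can therefore also move the read-out upward, with 2H-tetrazol-5-yl giving an at least 5.3-fold higher number from compound 3 to compound 4 (0.72 log units; beyond the scatter). Against the sulfonyl-bearing groups, the same change gives an at least 5000-fold higher number from compound 2 to compound 4 (3.69 log units; beyond the scatter) and an at least 81-fold higher number from compound 1 to compound 4 (1.91 log units; beyond the scatter), so the spread at this position is wider than the three earlier compounds showed.

On these data alone, how far the true value of compound 4 lies past the limit stays open. Also open, as far as these compounds go, is whether a carboxylic acid at this position would read closer to compound 4 or to compound 1.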